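Removing the carbamoyl link: what to expect for compound 4

The compounds below may be only part of what the source reports. "The series", "measured", "known", "first", "only" and "open" are said of these compounds alone.

Measured in a functional assay on MCF7 cells (Homo sapiens) for inhibition, read by MTT assay, with a stated time of 72 h; on this read-out higher numbers stand for weaker inhibition and lower numbers for stronger inhibition:
compound 1 `COc1cc(NC(C)CCCNC(=O)Nc2ccc(Br)cc2)c2ncccc2c1` gives 2600 nM
compound 2 `COc1cc(NC(C)CCCNC(=O)NNC(=O)Nc2ccc(Cl)cc2)c2ncccc2c1` gives 180 nM
compound 3 `COc1cc(NC(C)CCCNC(=O)NNC(=O)Nc2ccc(C(F)(F)F)cc2)c2ncccc2c1` gives 100 nM

Compound 2 stands at the low end of these numbers, together with compound 3. The step between those two is small (see a 1.8-fold lower number from compound 2 to compound 3 (0.26 log units; within the scatter)). The large step in the set is a 14-fold lower number from compound 1 to compound 2 (1.16 log units; beyond the scatter) and sets compound 2 well apart from compound 1.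

The next compound is compound 4 `COc1cc(NC(C)CCCNC(=O)Nc2cccc(O)c2)c2ncccc2c1`, in which 3-hydroxyphenyl takes the place of ((4-chlorophenyl)carbamoyl)amino on an amide-type nitrogen (3-hydroxyphenyl in place of ((4-chlorophenyl)carbamoyl)amino on an amide-type nitrogen). The group that leaves is the one that entered in a 14-fold lower number from compound 1 to compound 2 (1.16 log units; beyond the scatter), so that large step, read backwards, is the best guide. The step of a 1.8-fold lower number from compound 2 to compound 3 (0.26 log units; within the scatter) bears little on it, since it concerns another exchange. Going by the values given here, no measured compound carries 3-hydroxyphenyl, so the size remains uncertain. A large move towards a higher number is expected in this assay, and the estimated step is a 12-fold higher number from compound 2 to compound 4 (1.09 log units; beyond the scatter) (an expectation only). For compound 4 the estimated value is 2200 nM (expected range 700 nM to 7000 nM).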

Compound 4, half-maximal inhibitory concentration: 11000 nM
Compound 4: the middle estimate sits 5.0-fold (0.70 log units) below what was measured, outside the stated range (above it).
By their numbers in this assay, from the lowest: compounds 3 and 2 (each within the scatter of the next); then compound 1; then compound 4.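

In this assay, the group on this amide-type nitrogen still matters once the carbamoyl link is gone: 3-hydroxyphenyl in place of 4-bromophenyl gives a 4.2-fold higher number from compound 1 to compound 4 (0.63 log units; beyond the scatter). Putting 3-hydroxyphenyl in place of ((4-chlorophenyl)carbamoyl)amino gives a much larger change, a 61-fold higher number from compound 2 to compound 4 (1.79 log units; beyond the scatter), so among these compounds the two without that link, compound 1 and compound 4, both have much higher numbers than compound 2. No measurement available here explains why these changes have these effects.

Compound 4 differs from compound 1 in both the substituent and its place on the phenyl ring, so the effects of these two differences cannot be separated. Going by these compounds, it also remains open whether an amine or a carboxylic acid in place of the hydroxyl would give a lower or a higher number.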